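From Methylsulfonyl to Formyl on an Aromatic Carbon

This account rests on a few compounds, and the source may have more. Where it says the series, first, only, none or still open, it means among the compounds named here.

Measured compounds:
compound 1, `CC(Oc1ccccc1Br)C1=NCCN1`, 316 nM
compound 2, `COc1ccccc1OC(C)C1=NCCN1`, 100000 nM
compound 3, `CC(Oc1ccccc1S(C)(=O)=O)C1=NCCN1`, 10000 nM

Three compounds share one core and differ only in the group on an aromatic carbon. In a functional assay on CHO cells for agonist activity at Alpha-2B adrenergic receptor (Homo sapiens) (on this read-out lower numbers stand for an effect already at smaller amounts and higher numbers for an effect only at larger amounts of compound), compound 1 gives 316 nM, compound 2 gives 100000 nM and compound 3 gives 10000 nM. Compound 3 thus stands second highest of the three numbers: a 10-fold lower number from compound 2 to compound 3 (1.00 log units; beyond the scatter), while a 32-fold higher number from compound 1 to compound 3 (1.50 log units; beyond the scatter).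

Compound 4, `CC(Oc1ccccc1C=O)C1=NCCN1`, has not yet been measured in this assay. It differs from compound 3 in a single place: formyl in place of methylsulfonyl on an aromatic carbon. The two steps that bear on this change both replace the group on the same aromatic carbon, and both were large: a 32-fold higher number from compound 1 to compound 3 (1.50 log units; beyond the scatter) and a 10-fold lower number from compound 2 to compound 3 (1.00 log units; beyond the scatter). A formyl group, however, has not been tried here, so neither step tells directly how it will behave. Given that each swap on this carbon so far moved the number well beyond the scatter, a change of similar size in either direction for compound 4 is expected, with the estimate leaning toward the middle of the three measured values. For compound 4 an expected value of 3000 nM is estimated, with a range from 500 nM to 20000 nM, which would mean a 3.3-fold lower number from compound 3 to compound 4 (0.52 log units; beyond the scatter).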

Compound 4, half-maximal effective concentration: 316 nM
Estimate against measurement, compound 4: 9.5-fold (0.98 log units) above, and the stated range ends above it.
By their numbers in this assay, from the lowest: compounds 1 and 4 (each within the scatter of the next); then compound 3; then compound 2.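

In this assay, formyl is the only one of the three replacements of bromo on this aromatic carbon that leaves the number where it was: the result is no change at the digits printed from compound 1 to compound 4 (within the scatter) while methoxy in compound 2 and methylsulfonyl in compound 3 both gave large rises. Swapping methylsulfonyl for formyl gives a 32-fold lower number from compound 3 to compound 4 (1.50 log units; beyond the scatter) and swapping methoxy for formyl gives a 320-fold lower number from compound 2 to compound 4 (2.50 log units; beyond the scatter) on the same carbon, so the low end of the range at this position is no longer held by bromo alone but is shared by two different groups. Nothing measured here accounts for why these groups fall where they do.

From the compounds shown here alone, it remains open whether an amine, a carboxylic acid or a nitrile on this aromatic carbon would stay level with bromo and formyl or move toward the higher numbers of compound 3 and compound 2. The compounds shown also leave open how a longer chain, such as an acetyl or a propanoyl group in place of formyl, would behave at this position on the shared core.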